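Fluorophenyl in place of cyanophenyl: a weaker compound expected

The source may hold more compounds than are shown below. What is called first, only, known or untested is meant among the compounds shown, and "the series" means these compounds.

Of the compounds shown here, three have so far been measured in a functional assay on HL-60 cells (Homo sapiens) for antiproliferative activity, read by sulforhodamine B assay, with a stated time of 72 h; a higher number here means a weaker inhibitor, a lower number a stronger inhibitor. Compound 1 `CN(C)C(=S)N/N=C/c1cc2cccnc2s1` reaches only the limit of this assay, > 100000 nM. Compound 2 `N#Cc1ccc(NC(=S)N/N=C/c2ccc3ccccc3n2)cc1` gives 4660 nM in this assay. Compound 3 `FC(F)(F)c1ccc(NC(=S)N/N=C/c2ccc3ccccc3n2)cc1` gives 34900 nM in this assay. Among the two real numbers, compound 2 stands lowest; its nearest neighbour is compound 3, and the change of trifluoromethyl in place of cyano on an aromatic carbon brings a 7.5-fold higher number from compound 2 to compound 3 (0.87 log units; beyond the scatter), a modest step that nonetheless lies beyond the scatter.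

Compound 4 `Fc1cccc(NC(=S)N/N=C/c2ccc3ccccc3n2)c1` is the next compound to be measured. It differs from compound 2 in one place: 3-fluorophenyl in place of 4-cyanophenyl on an amide-type nitrogen. Among the measured compounds shown here, the only measured step that bears on this change is the one from compound 2 to compound 3, in which the cyano on the aryl group attached to the amide-type nitrogen was likewise exchanged for another substituent, and the number rose by a 7.5-fold higher number from compound 2 to compound 3 (0.87 log units; beyond the scatter). Compound 4 exchanges the 4-cyanophenyl for 3-fluorophenyl, so a rise of comparable, perhaps slightly smaller, size is expected. The expected step is a 4.3-fold higher number from compound 2 to compound 4 (0.63 log units; beyond the scatter). Compound 4 is therefore estimated at 20000 nM, with a range from 6000 nM to 60000 nM.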

Compound 4, half-maximal inhibitory concentration: 43800 nM
For compound 4 the middle estimate is 2.2-fold (0.34 log units) below the measured one; the range from low to high includes it.
By their numbers in this assay, from the lowest: compound 2; then compounds 3 and 4 (each within the scatter of the next). At a limit, above all of these: compound 1.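

In this assay, 3-fluorophenyl in place of 4-cyanophenyl on the amide-type nitrogen gives a 9.4-fold higher number from compound 2 to compound 4 (0.97 log units; beyond the scatter), so a second, different replacement of the 4-cyanophenyl group also leaves compound 2 with the lowest number of the compounds that have real values. Compound 3 and compound 4 lie within the scatter of each other, so these two replacements, one carrying trifluoromethyl and the other fluorine, cannot be told apart in this assay, and both stand clearly apart from compound 2. Nothing among the measurements shown bears on why the number changes with this exchange.

Compound 4 differs from compound 2 both in the substituent and in where it sits, as the names 4-cyanophenyl and 3-fluorophenyl show, so the compounds shown cannot say which of the two accounts for the step. Going by these compounds, how 3-cyanophenyl or 4-fluorophenyl would stand on this nitrogen remains open, as does the effect of a phenyl group bearing an amine or a carboxylic acid.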